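Changing One Side Group on a Potent Inhibitor

The compounds below may be only part of what the source reports. "The series", "measured", "known", "first", "only" and "open" are said of these compounds alone.

Compound 1 `CN(c1ccc(N/C(S)=N/c2ccccc2)cc1)c1ccnc(Nc2cccc(CS(C)(=O)=O)c2)n1`: 6 nM
Compound 2 `CN(c1ccc(NC(=O)Nc2ccccc2)cc1)c1ccnc(Nc2cccc(S(N)(=O)=O)c2)n1`: 2 nM

In a functional assay on HUVEC cells (Homo sapiens) for inhibition (on this read-out lower numbers stand for stronger inhibition and higher numbers for weaker inhibition), compound 1 gives 6 nM, the higher of the two numbers, while compound 2 gives 2 nM, a gap beyond the usual scatter. Compound 3 `CN(c1ccc(NC(=O)Nc2c(Cl)cccc2Cl)cc1)c1ccnc(Nc2cccc(CS(C)(=O)=O)c2)n1` has not yet been measured. Its structure departs from compound 1 as follows: a group of 11 heavy atoms (7 carbon, 1 nitrogen, 1 oxygen, 2 chlorine; one six-membered aromatic ring of carbon only) in place of a group of 9 heavy atoms (7 carbon, 1 nitrogen, 1 sulfur; one six-membered aromatic ring of carbon only), on a nitrogen on an aromatic ring. Among the compounds with values here, no measured pair shows this change, so the expectation rests on the value of compound 1 at 6 nM, and no shift beyond the scatter is expected. The expected step is a 1.2-fold lower number from compound 1 to compound 3 (0.08 log units; within the scatter). The estimated value for compound 3 is 5 nM, within a range of 1.5 nM to 20 nM.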

Compound 3, half-maximal inhibitory concentration: 29 nM
Beside the measured number, compound 3's estimate is 5.8-fold (0.76 log units) below it; the measured number lies above the stated range.
By their numbers in this assay, from the lowest: compound 2; then compound 1; then compound 3.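

Swapping the sulfur-bearing group on this aromatic-ring nitrogen for (2,6-dichlorophenyl)carbamoyl gives a 4.8-fold higher number from compound 1 to compound 3 (0.68 log units; beyond the scatter) in this assay. Within the data shown here, this is the first pair differing in one place, and it shows that inhibition at this position responds to the change, weakening beyond the usual scatter. No measurement here bears on the reason for this rise.

As far as these compounds go, the sulfur and the two chlorine atoms changed together, so their separate contributions remain open. Also open, from the compounds shown here alone, is how methyl groups in place of those chlorine atoms would read out.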